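A few compounds are considered here, and "the series" means these few. Any claim that something is new, unique, unknown or untested is made for them only; others in the source may bear on it.

Measured so far:
- compound 1, `COCc1cccc(C[C@H](O)/C=C/[C@H]2[C@H](O)CC(=O)[C@@H]2CCSCCCC(=O)O)c1`: 1.6 nM
- compound 2, `CCCCC[C@H](O)/C=C/[C@H]1[C@H](O)CC(=O)[C@@H]1CSCCCCC(=O)O`: 1000 nM

In a functional assay on cells with prostaglandin E2 receptor EP4 subtype (Mus musculus) as the target (on this read-out lower numbers stand for an effect already at smaller amounts and higher numbers for an effect only at larger amounts of compound), compound 2 gives 1000 nM, the highest of the two numbers; the nearest value, that of compound 1, lies far below, beyond the scatter. Compound 3, `CCCCC[C@H](O)/C=C/[C@H]1[C@H](O)CC(=O)[C@@H]1CCSCCCC(=O)O`, has not been measured. Among the compounds with values here, it differs from compound 2 by ((3-carboxypropyl)sulfanyl)methyl in place of (4-carboxybutyl)sulfanyl on a saturated chain carbon bound to a saturated ring carbon, so the same atoms are joined differently; no step of this kind between measured compounds is available. Compound 1 with 1.6 nM shows that this series reaches numbers far below that of compound 2, so a large downward step from compound 2 to compound 3 is expected, though its size is uncertain because the change in the omega chain of compound 1 is not separated out. The expected step from compound 2 to compound 3 is a 33-fold lower number from compound 2 to compound 3 (1.52 log units; beyond the scatter). For compound 3 the estimate is 30 nM, with a range from 4 nM to 250 nM.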

Compound 3, half-maximal effective concentration: 3.6 nM
Estimate against measurement, compound 3: 8.3-fold (0.92 log units) above; the whole stated range lies above it.
By their numbers in this assay, from the lowest: compound 1; then compound 3; then compound 2.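

In this assay, ((3-carboxypropyl)sulfanyl)methyl in place of (4-carboxybutyl)sulfanyl gives a 280-fold lower number from compound 2 to compound 3 (2.44 log units; beyond the scatter), so with identical atoms, how they are joined on this saturated chain carbon bound to a saturated ring carbon is enough for a large change. Butyl in place of 3-(methoxymethyl)phenyl, by contrast, gives only a 2.3-fold higher number from compound 1 to compound 3 (0.35 log units; beyond the scatter), a modest step though beyond the scatter, which means that compound 3 reaches the low range of the series without the aromatic group of compound 1. No available data explain either step.

Open, from the compounds shown here alone, is whether the sulfur itself matters: an ether oxygen or a methylene at that point in the chain would test this. Equally open, going by these compounds, is how a shorter or longer chain ending in the carboxylic acid would read.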